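The source may report more compounds than this note shows. Statements on the series, on what has been measured and on what is new or still open speak of the compounds shown alone.

- compound 1 `CCCCn1nc(C(=O)N[C@H]2COc3ccccc3N(C)C2=S)nc1Cc1ccccc1`: 510 nM
- compound 2 `CN1C(=S)[C@@H](NC(=O)c2nc(Cc3ccccc3)n(C3CCC3)n2)COc2ccccc21`: 181 nM

In a functional assay on HT-29 cells (Homo sapiens) for inhibition, read by luminescence and CellTiter-Glo, with a stated time of 24 h (on this read-out higher numbers stand for an effect only at larger amounts of compound and lower numbers for an effect already at smaller amounts), compound 2 gives the lower of the two numbers, 181 nM. Compound 3 `CN1C(=S)[C@@H](NC(=O)c2nc(Cc3ccccc3)n(C3CCOCC3)n2)COc2ccccc21` keeps the rest of compound 2 but carries oxan-4-yl in place of cyclobutyl on an aromatic nitrogen. Among the measured compounds shown here, only one measured step concerns this nitrogen: a 2.8-fold lower number from compound 1 to compound 2 (0.45 log units; beyond the scatter), a modest change made by putting cyclobutyl in place of butyl. For the measured compounds named here, no measured compound has an oxygen in the group at this place, so that step is only a rough guide to size. A modest step is expected again in this assay, and the direction is a tentative guess, towards a higher number. The estimated change is a 2.1-fold higher number from compound 2 to compound 3 (0.32 log units; beyond the scatter). For compound 3 the estimate is 380 nM, with an expected range from 120 nM to 1200 nM.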

Compound 3, half-maximal effective concentration: 2260 nM
For compound 3 the middle estimate is 5.9-fold (0.77 log units) below the measured one, and the stated range ends below it.
By their numbers in this assay, from the lowest: compound 2; then compound 1; then compound 3.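

In this assay, this nitrogen proves far more sensitive to its substituent than the earlier modest step suggested: oxan-4-yl in place of cyclobutyl gives a 12-fold higher number from compound 2 to compound 3 (1.10 log units; beyond the scatter), a large step. Oxan-4-yl in place of butyl also raises the number, with a 4.4-fold higher number from compound 1 to compound 3 (0.65 log units; beyond the scatter), so having a ring on this nitrogen does not by itself give a lower number than the open chain. No evidence is available on why the step from cyclobutyl to oxan-4-yl is so large.

Ring size and the ring oxygen change together in compound 3, and the compounds shown cannot tell which of the two goes with the higher number. A cyclohexyl group, with a six-membered ring of carbon only, or a small oxetan-3-yl group on this nitrogen could begin to pull these two changes apart.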